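The source may hold more compounds than are shown below. What is called first, only, known or untested is meant among the compounds shown, and "the series" means these compounds.

Compound 1: `O=C(CCCc1ccccc1)Nc1nc2ccccc2c(=O)s1`, 34.9 nM
Compound 2: `O=C(CCc1ccccc1F)Nc1nc2ccccc2c(=O)s1`, 11.2 nM

In an in vitro assay on cells for inhibition of Amine oxidase [flavin-containing] B (Homo sapiens), read by fluorescence and Amplex Red, with stated times of 30 min and 45 min (a lower number here means a stronger inhibitor, a higher number a weaker inhibitor), compound 1 holds the highest of the two numbers. Among the measured compounds shown here, the only measured step, a 3.1-fold lower number from compound 1 to compound 2 (0.49 log units; beyond the scatter), changes the chain and its aryl group, not the amide nitrogen. Compound 3 `CN(C(=O)CCCc1ccccc1)c1nc2ccccc2c(=O)s1` differs from compound 1 by methyl in place of hydrogen on an amide-type nitrogen. For the measured compounds named here, no measured step touches that nitrogen, so the data give no direction for this change, and the estimate must be wide. For compound 3 a step of a 2.9-fold higher number from compound 1 to compound 3 (0.46 log units; beyond the scatter) is expected, giving an estimated 100 nM with a range from 20 nM to 600 nM.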

Compound 3, half-maximal inhibitory concentration: 53.1 nM
The estimate for compound 3 lay 1.9-fold (0.27 log units) above the measured number; low and high end bracket the measured number.
By their numbers in this assay, from the lowest: compound 2; then compounds 1 and 3 (each within the scatter of the next).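

Methyl in place of the amide hydrogen gives a 1.5-fold higher number from compound 1 to compound 3 (0.18 log units; within the scatter) and so, for this pair, the hydrogen on this nitrogen can be replaced without a change that stands out from the scatter. Among the compounds shown here, this is the first measured change at this nitrogen, and it shows that inhibition survives the loss of the amide hydrogen on the chain of compound 1. No supporting evidence is available to explain this result.

On these data alone, whether an ethyl or cyclopropyl group on this nitrogen would give a similar number remains open. So does the effect of methyl here on the 2-fluorophenyl chain of compound 2.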